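Adding Chloro to the Pendant Phenyl of Compound 2

This account rests on a few compounds, and the source may have more. Where it says the series, first, only, none or still open, it means among the compounds named here.

Three related compounds have been tested in a functional assay on MCF7 cells (Homo sapiens) for cytotoxicity, read by MTT assay, with a stated time of 24 h; on this read-out higher numbers stand for weaker inhibition and lower numbers for stronger inhibition. Compound 1 `Cc1cc(O)c(C(=O)/C=C/c2ccc(OCc3ccccc3)cc2)c(-c2ccccc2)c1C(=O)/C=C/c1ccc(OCc2ccccc2)cc1` gives 10000 nM. Compound 2 `Cc1cc(O)c(C(=O)/C=C/c2ccc3ccccc3c2)c(-c2ccccc2)c1C(=O)/C=C/c1ccc2ccccc2c1` gives 31500 nM, the highest of the two numbers and beyond the scatter from compound 1. Compound 3 `Cc1cc(O)c(C(=O)/C=C/c2ccc(Cl)cc2)c(-c2ccc(OCc3ccccc3)cc2)c1C(=O)/C=C/c1ccc(Cl)cc1` is reported as "not active" (no number reported), without a number. Compound 4 `Cc1cc(O)c(C(=O)/C=C/c2ccc3ccccc3c2)c(-c2ccc(Cl)cc2)c1C(=O)/C=C/c1ccc2ccccc2c1` is not yet measured; it differs from compound 2 in one place: chloro in place of hydrogen on an aromatic carbon. Within the data shown here, no pair of measured compounds differs by exactly this change, so nothing here shows its size. Because compound 2 already gives 31500 nM in this assay, the expected step is a 1.3-fold higher number from compound 2 to compound 4 (0.10 log units; within the scatter), none beyond the scatter in either direction. Compound 4 is therefore estimated at 40000 nM, within a range from 15000 nM to 100000 nM.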

Compound 4, half-maximal inhibitory concentration: "not active" (no number reported)
No number was reported for compound 4, and the estimate cannot be compared.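

Among these compounds, compound 4 is reported without a number, so no step from compound 2 can be read. No measurement shown offers an explanation for this result. On these data alone, how far the change from phenyl to 4-chlorophenyl shifts the number in this assay remains open.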